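The compounds below may be only part of what the source reports. "The series", "measured", "known", "first", "only" and "open" are said of these compounds alone.

Of the compounds shown here, three from one series have been tested for how quickly they are broken down in an ADME assay on microsomes from liver (Homo sapiens) for metabolic stability, tested at 2.5 uM; on this read-out higher numbers stand for fast clearance and lower numbers for slow clearance. Compound 1, `COc1ccc(-c2c(S(=O)(=O)c3ccc(C)c(C)c3)cnc3cc(F)ccc23)cc1`, gives 4.13 mL/min in this assay. Compound 2, `Cc1ccc(S(=O)(=O)c2cnc3cc(F)ccc3c2-c2cccc(Cl)c2)cc1C`, gives 4.01 mL/min. Compound 3, `O=S(=O)(c1ccc(F)c(F)c1)c1cnc2c(F)cccc2c1-c1cccc(Cl)c1`, gives 1.13 mL/min, the lowest of the three numbers, and its gap to both of the others is beyond the usual scatter of the measurement.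

Compounds 1 and 2 share a core and differ in one place: 4-methoxyphenyl in place of 3-chlorophenyl on an aromatic carbon. The step this change made is a 1.0-fold higher number from compound 2 to compound 1 (0.01 log units; within the scatter), so the two numbers cannot be told apart. The difference between the core of compound 2 and the core of compound 3 is not broken down here.

Compound 4, `COc1ccc(-c2c(S(=O)(=O)c3ccc(F)c(F)c3)cnc3c(F)cccc23)cc1`, has not yet been measured. It relates to compound 3 in the same way that compound 1 relates to compound 2: 4-methoxyphenyl in place of 3-chlorophenyl on an aromatic carbon. The place of the change is described in the same words for both pairs, so this is the same change made on a different core.

Since the step from compound 2 to compound 1 stayed within the scatter, compound 4 is expected to stay close to compound 3, with an expected step of a 1.1-fold higher number from compound 3 to compound 4 (0.03 log units; within the scatter). The estimate for compound 4 in this assay is therefore 1.2 mL/min, likely falling between 0.6 mL/min and 2.4 mL/min. The measured number will show whether the change behaves alike on both cores.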

Compound 4, intrinsic clearance in a liver preparation (reported as CLH), per the amount of preparation that the assay uses: 2.12 mL/min
The estimate for compound 4 lay 1.8-fold (0.25 log units) below the measured number; the range from low to high includes it.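

In this assay, putting 4-methoxyphenyl in place of 3-chlorophenyl gives a 1.9-fold higher number from compound 3 to compound 4 (0.27 log units; within the scatter) on the second core, so here too the change stays inside the normal spread of repeated measurements. Set beside the earlier step, the two results cannot be told apart, which means that, as far as this read-out can tell, the change carries over from one core to the other: the same change on two cores in this assay, a 1.0-fold higher number (0.01 log units; within the scatter) from compound 2 to compound 1 and a 1.9-fold higher number (0.27 log units; within the scatter) from compound 3 to compound 4, 1.8-fold (0.26 log units) apart, within the scatter of two such steps. This does not show that the change has no effect at all, since a small real shift could be hidden within the scatter, and two cores are too few to support a rule for the whole series.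

The compounds shown have only 3-chlorophenyl or 4-methoxyphenyl at this place on the ring, so it remains open whether a group of a different kind, such as an amine or a carboxylic acid, would leave the clearance number just as undisturbed. Also open is which of the several differences between the two cores matters for this read-out, as no pair shown isolates any one of them.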